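Halogen position swap on the benzylidene arm

This account rests on a few compounds, and the source may have more. Where it says the series, first, only, none or still open, it means among the compounds named here.

Measured compounds:
- compound 1, `C=CCn1c(=O)/c(=C\c2cccc(Cl)c2)[nH]c(=O)/c1=C\c1ccccc1OC`: 4900 nM
- compound 2, `C=CCn1c(=O)/c(=C\c2cccc(F)c2)[nH]c(=O)/c1=C\c1ccccc1OC`: 6500 nM

Both were read in a functional assay on MOLT-4 cells (Homo sapiens) for cytotoxicity, read by CCK-8 assay, with a stated time of 72 h; on this read-out lower numbers stand for stronger inhibition and higher numbers for weaker inhibition. Compound 2 gives 6500 nM and compound 1 gives 4900 nM; the two numbers lie within the scatter of each other, so compound 2 stands level with compound 1 and no order between them can be drawn.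

The next compound, compound 3 `C=CCn1c(=O)/c(=C\c2ccccc2Cl)[nH]c(=O)/c1=C\c1ccccc1OC`, differs from compound 2 by 2-chlorophenyl in place of 3-fluorophenyl on a double-bonded chain carbon bound to an aromatic carbon. Going by the values given here, the only measured step, a 1.3-fold higher number from compound 1 to compound 2 (0.12 log units; within the scatter), concerns a halogen exchange at the same aromatic carbon and did not move the number beyond the scatter. No measured pair speaks to moving the halogen to another ring carbon, so the position change is untested here; the halogen exchange itself has shown no effect. On this basis the step to compound 3 is expected to stay within the scatter in this assay, with no clear direction, giving an expected step of a 1.2-fold lower number from compound 2 to compound 3 (0.07 log units; within the scatter).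

Compound 3 is therefore estimated at 5500 nM, with a range of 2000 nM to 16000 nM, the width reflecting the untested position change.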

Compound 3, half-maximal inhibitory concentration: 4400 nM
Compound 3: middle estimate off by 1.3-fold (0.10 log units), on the high side, within the range that was stated.
By their numbers in this assay, from the lowest: compounds 3, 1 and 2 (each within the scatter of the next).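

In this assay, going by these compounds alone, moving the chlorine gives the first direct reading on halogen position: 2-chlorophenyl in place of 3-chlorophenyl produces a 1.1-fold lower number from compound 1 to compound 3 (0.05 log units; within the scatter) and leaves the number unchanged within the scatter. Changing the halogen and its position together gives a 1.5-fold lower number from compound 2 to compound 3 (0.17 log units; within the scatter) and also stays within the scatter, so this pair shows no added shift from the two changes combined. Compound 1, compound 2 and compound 3 therefore stand level, and no preference among 3-chlorophenyl, 3-fluorophenyl and 2-chlorophenyl can be drawn on this double-bonded chain carbon; no further data bear on the result.

From the compounds shown here alone, all three compounds carry one halogen on this aromatic ring, so it remains open whether a different kind of group there, such as a dimethylamino group or a carboxylic acid, would move the number beyond the scatter. Going by these compounds, the effect of fluoro in place of the chloro of compound 3 also remains open, as does any change to the shared core or to the methoxy-bearing arm.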